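This account rests on a few compounds, and the source may have more. Where it says the series, first, only, none or still open, it means among the compounds named here.

Measured in a functional assay on HCT-116 cells (Homo sapiens) for antiproliferative activity, read by MTT assay, with a stated time of 24 h; on this read-out higher numbers stand for weaker inhibition and lower numbers for stronger inhibition:
Compound 1 `COc1cc(OC)c(-c2coc3cc(OCC(=O)c4cccc(C(F)(F)F)c4)ccc3c2=O)cc1OC`: > 10000 nM, a limit of the assay and not a number
Compound 2 `COc1cc(OC)c(-c2coc3cc(OCc4ccccc4C(F)(F)F)ccc3c2=O)cc1OC`: 4760 nM
Compound 3 `COc1cc(OC)c(-c2coc3cc(OCc4ccc(C#N)cc4)ccc3c2=O)cc1OC`: 4220 nM

Only compound 2 and compound 3 give actual numbers, and the two cannot be told apart: the step between them is a 1.1-fold lower number from compound 2 to compound 3 (0.05 log units; within the scatter). Compound 3 therefore stands level with compound 2, and both stand clear of compound 1, as the steps of an at least 2.1-fold lower number from compound 1 to compound 2 (0.32 log units; beyond the scatter) and an at least 2.3-fold lower number from compound 1 to compound 3 (0.37 log units; beyond the scatter) show. On these data alone, those two steps are bounded only by the limit of > 10000 nM in this assay, at which 1 of the 3 values shown sits, so their true size is unknown.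

Compound 4 `COc1cc(OC)c(-c2coc3cc(OCc4ccccc4C#N)ccc3c2=O)cc1OC` keeps everything in compound 3 except the placing of the nitrile on the phenyl ring: 2-cyanophenyl in place of 4-cyanophenyl on a saturated chain carbon bound to an oxygen on an aromatic ring. In words, 2-cyanophenyl stands in place of 4-cyanophenyl on a saturated chain carbon bound to an oxygen on an aromatic ring.

For the measured compounds named here, no measured step makes exactly this change. The closest guide is the step of a 1.1-fold lower number from compound 2 to compound 3 (0.05 log units; within the scatter), which exchanges 2-(trifluoromethyl)phenyl for 4-cyanophenyl at the same place and stays within the scatter. The large gaps involve only compound 1, whose linking carbonyl compound 4 lacks. The expected result in this assay is therefore no change beyond the scatter, with the step estimated as a 1.1-fold higher number from compound 3 to compound 4 (0.03 log units; within the scatter). The estimated value for compound 4 is 4500 nM, with an expected range of 2200 nM to 9500 nM.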

Compound 4, half-maximal inhibitory concentration: > 10000 nM
Compound 4 was reported as a limit (the forecaster's own chance of this, stated with the estimate: 15%); middle value at least 2.2-fold (0.34 log units) away from the limit.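

The placing of the nitrile on the phenyl ring matters at this position, even though the atoms stay the same: in this assay the change from 4-cyanophenyl to 2-cyanophenyl gives an at least 2.3-fold higher number from compound 3 to compound 4 (0.37 log units; beyond the scatter). The group also matters when its ring placing is kept, since nitrile in place of trifluoromethyl gives an at least 2.1-fold higher number from compound 2 to compound 4 (0.32 log units; beyond the scatter), so the level standing seen earlier, a 1.1-fold lower number from compound 2 to compound 3 (0.05 log units; within the scatter), does not mean that this position accepts any change. The result for compound 4 is a limit of the assay and not a number, so these steps give only a least size and the step from compound 1 to compound 4 cannot be read: the limit of > 10000 nM in this assay, at which 2 of the 4 values shown sit.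

On these data alone, with only these compounds, it stays open whether the loss belongs to the nitrile specifically, since compound 2 keeps a measurable value with trifluoromethyl on its ring. As far as these compounds go, it is also open how a carboxylic acid or an amine in place of the nitrile on the phenyl ring would read in this assay, and whether any such group would bring the value clearly below those of compound 2 and compound 3.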